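The source may report more compounds than this note shows. Statements on the series, on what has been measured and on what is new or still open speak of the compounds shown alone.

In a functional assay on LOX cells (Homo sapiens) for antiproliferative activity, read by WST assay, with a stated time of 3 days (a higher number here means a weaker inhibitor, a lower number a stronger inhibitor), compound 1 (`[N-]=[N+]=Nc1cc(=O)[nH]c(=O)n1[C@@H]1O[C@H](CO)[C@@H](O)[C@H]1O`) gives > 50000 nM as a limit, not a number. Compound 2 (`CN(C)c1cc(=O)[nH]c(=O)n1[C@@H]1O[C@H](CO)[C@@H](O)[C@H]1O`) gives > 50000 nM as a limit too. Compound 3 (`O=Cc1cc(=O)[nH]c(=O)n1[C@@H]1O[C@H](CO)[C@@H](O)[C@H]1O`) gives > 50000 nM as a limit too. Going by the values given here, the series so far shows only the limit of > 50000 nM in this assay, at which 3 of the 3 values shown sit, and nothing finer. Compound 4 (`[N-]=[N+]=Nc1c(F)c(=O)[nH]c(=O)n1[C@@H]1O[C@H](CO)[C@@H](O)[C@H]1O`) differs from compound 1 by fluoro in place of hydrogen on an aromatic carbon (fluoro in place of hydrogen on an aromatic carbon, ortho to an azido group). The measured steps are a step that the two limits leave unreadable from compound 1 to compound 2 and a step that the two limits leave unreadable from compound 1 to compound 3 and also a step that the two limits leave unreadable from compound 2 to compound 3 with no size to carry over, and none of them replaces that hydrogen. Only a small move toward stronger inhibition is therefore expected, with an at least 1.6-fold lower number from compound 1 to compound 4 (0.22 log units; that floor lies within the scatter) as the estimated step and another limit quite possible. The estimated value for compound 4 is 30000 nM with 3000 nM to 80000 nM as the expected range.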

Compound 4, half-maximal inhibitory concentration: 2300 nM
Beside the measured number, compound 4's estimate is 13-fold (1.12 log units) above it; measured number outside the range, below it.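

In this assay, fluoro in place of hydrogen on an aromatic carbon, ortho to an azido group, gives an at least 21-fold lower number from compound 1 to compound 4 (1.33 log units; beyond the scatter), so this position responds to a single added atom. The steps among compound 1, compound 2 and compound 3 cannot be read, and compound 4 alone gives a number rather than a limit: the limit of > 50000 nM in this assay, at which 3 of the 4 values shown sit.

On these data alone, whether chloro or methyl in place of that hydrogen would do the same stays open. So does whether fluoro keeps this effect with dimethylamino or formyl in place of azido.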